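This account rests on a few compounds, and the source may have more. Where it says the series, first, only, none or still open, it means among the compounds named here.

Working notes on the urea series. Compound 1 `O=C(Nc1cccc(CNc2nccnc2Cl)c1)Nc1ccccc1Cl` gives 6680 nM in a functional assay on T-24 cells (Homo sapiens) for antiproliferative activity, read by MTT assay, with a stated time of 48 h; on this read-out lower numbers stand for stronger inhibition and higher numbers for weaker inhibition. Compound 2 `O=C(Nc1ccccc1)Nc1cccc(CNc2nccnc2Cl)c1` gives 19800 nM, and compound 3 `Cc1cccc(NC(=O)Nc2cccc(CNc3nccnc3Cl)c2)c1` gives 9570 nM. Compound 3 stands second highest of the three numbers: its nearest neighbour is compound 1, a 1.4-fold higher number from compound 1 to compound 3 (0.16 log units; within the scatter), and its furthest is compound 2, a 2.1-fold lower number from compound 2 to compound 3 (0.32 log units; beyond the scatter). The other step in the set, a 3.0-fold higher number from compound 1 to compound 2 (0.47 log units; beyond the scatter), also turns on a substituent of the aryl group on the amide-type nitrogen.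

Compound 4 `COc1ccc(NC(=O)Nc2cccc(CNc3nccnc3Cl)c2)cc1` is not yet measured. It differs from compound 3 in one place: 4-methoxyphenyl in place of 3-methylphenyl on an amide-type nitrogen. The most direct precedent is the earlier aryl exchange at the same nitrogen, a 1.4-fold higher number from compound 1 to compound 3 (0.16 log units; within the scatter), which stayed within the scatter. The two substituent steps, a 3.0-fold higher number from compound 1 to compound 2 (0.47 log units; beyond the scatter) and a 2.1-fold lower number from compound 2 to compound 3 (0.32 log units; beyond the scatter), show that removing a ring substituent raised the number modestly, while adding one lowered it; both compound 1 and compound 3 sit below unsubstituted compound 2. A substituted aryl is retained in compound 4, so the expected step of a 1.1-fold higher number from compound 3 to compound 4 (0.06 log units; within the scatter) is small and no direction beyond the scatter is assumed. Compound 4 is therefore estimated at 11000 nM, with a range of 5000 nM to 25000 nM.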

Compound 4, half-maximal inhibitory concentration: 9820 nM
For compound 4 the middle estimate is 1.1-fold (0.05 log units) above the measured one; the measured number falls inside the stated range.
By their numbers in this assay, from the lowest: compounds 1, 3, 4 and 2 (each within the scatter of the next, the first and the last beyond it).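

In this assay, the exchange of 3-methylphenyl for 4-methoxyphenyl on the amide-type nitrogen gives (a 1.0-fold higher number from compound 3 to compound 4 (0.01 log units; within the scatter)), so a group with one more heavy atom, an oxygen and a hydrogen-bond acceptor, leaves the number within the scatter of compound 3, and the exchange from 2-chlorophenyl (a 1.5-fold higher number from compound 1 to compound 4 (0.17 log units; within the scatter)) likewise stays within it. New here is that methoxy in place of hydrogen (a 2.0-fold lower number from compound 2 to compound 4 (0.30 log units; within the scatter)) also stays within the scatter, so compound 4 cannot be separated from unsubstituted compound 2, although the steps from compound 2 to compound 1 and to compound 3 are printed as beyond it; compound 4 therefore goes against any reading that a substituent on this aryl group separates a compound from compound 2. No evidence beyond these numbers bears on this result.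

The compounds shown leave open how an aryl group carrying an amine or a carboxylic acid would read here, and whether either would separate clearly from compounds 1, 3 and 4. Also open, as far as these compounds go, is how a longer chain in place of methoxy on the same aryl group would compare with compound 4.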